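Replacing the Substituted Phenyl Group of Compound 3

A few compounds are considered here, and "the series" means these few. Any claim that something is new, unique, unknown or untested is made for them only; others in the source may bear on it.

Measured in a functional assay on HepG2 cells (Homo sapiens) for cytotoxicity, read by MTT assay, with a stated time of 72 h; a lower number here means a stronger inhibitor, a higher number a weaker inhibitor:
- compound 1 `COc1cc2ncnc(Nc3ccc(F)c(Cl)c3)c2cc1NC(=O)N/N=C/c1ccc(F)cc1` gives 31100 nM
- compound 2 `COc1cc2ncnc(Nc3ccc(F)c(Cl)c3)c2cc1NC(=O)N/N=C/c1ccc([N+](=O)[O-])cc1` gives 34100 nM
- compound 3 `COc1cc2ncnc(Nc3ccc(F)c(Cl)c3)c2cc1NC(=O)N/N=C/c1ccc(O)c(Br)c1` gives 23800 nM

Compound 3, at 23800 nM, stands level with the other two compounds, since its differences from both lie within the scatter. The next structure, compound 4 `CCN(CC)c1ccc(/C=N/NC(=O)Nc2cc3c(Nc4ccc(F)c(Cl)c4)ncnc3cc2OC)c(O)c1`, carries 4-(diethylamino)-2-hydroxyphenyl in place of 3-bromo-4-hydroxyphenyl on a carbon with a double bond to nitrogen.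

Two measured steps made a change at this same place, a 1.3-fold lower number from compound 1 to compound 3 (0.12 log units; within the scatter) and a 1.4-fold lower number from compound 2 to compound 3 (0.16 log units; within the scatter). A third, a 1.1-fold higher number from compound 1 to compound 2 (0.04 log units; within the scatter), changed only the group on the aromatic ring. All three stayed within the scatter. Within the data shown here, none of the measured compounds carries a diethylamino group, so this evidence is indirect and the range must stay wide. In this assay, no change beyond the scatter is therefore expected, and the estimated step is a 1.1-fold lower number from compound 3 to compound 4 (0.03 log units; within the scatter). For compound 4 the expected value is 22000 nM, with an estimated range from 8000 nM to 50000 nM.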

Compound 4, half-maximal inhibitory concentration: 29300 nM
Beside the measured number, compound 4's estimate is 1.3-fold (0.12 log units) below it; measured number inside the range.
By their numbers in this assay, from the lowest: compounds 3, 4, 1 and 2 (each within the scatter of the next).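

In this assay, among these compounds, the position on the carbon with a double bond to nitrogen now holds 4-(diethylamino)-2-hydroxyphenyl, the first group here to carry a diethylamino substituent, and the number stays within the scatter of all three earlier compounds (a 1.2-fold higher number from compound 3 to compound 4 (0.09 log units; within the scatter); a 1.2-fold lower number from compound 2 to compound 4 (0.07 log units; within the scatter); a 1.1-fold lower number from compound 1 to compound 4 (0.03 log units; within the scatter)). The four compounds thus show no separation at this place, even with a group that brings more heavy atoms and a hydrogen-bond acceptor more than 3-bromo-4-hydroxyphenyl. No measurement available here accounts for this flat result.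

From the compounds shown here alone, whether a carboxylic acid, a primary amine or a longer alkyl chain on this phenyl ring would give a step beyond the scatter remains open. So does the effect of replacing the phenyl ring itself with a pyridine or a saturated ring such as piperidine.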